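This account rests on a few compounds, and the source may have more. Where it says the series, first, only, none or still open, it means among the compounds named here.

Measured so far:
compound 1 `Fc1ccccc1/C=C/c1ccccc1F` — 4300 nM
compound 2 `Fc1ccc(F)c(/C=C/c2ccccc2F)c1` — 5900 nM
compound 3 `Fc1ccccc1/C=C/c1c(F)cccc1F` — 1400 nM

All three numbers come from an assay on HepG2 cells for activation of nuclear factor erythroid 2-related factor 2 (Homo sapiens), read by a luciferase reporter, with a stated time of 5 h; on this read-out higher numbers stand for an effect only at larger amounts of compound and lower numbers for an effect already at smaller amounts. Compound 1 gives the second highest of the three. Of the two single-point steps from it, a 1.4-fold higher number from compound 1 to compound 2 (0.14 log units; within the scatter), whereas a 3.1-fold lower number from compound 1 to compound 3 (0.49 log units; beyond the scatter).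

Compound 4 `Fc1ccc(/C=C/c2ccccc2F)c(F)c1` is not yet measured. It differs from compound 1 by fluoro in place of hydrogen on an aromatic carbon, meta to a fluoro group and para to a group of 9 heavy atoms. Both measured steps from compound 1 are the same kind of change, placed elsewhere on the same ring: one stayed within the scatter, the other gave a modest lower number. Among the compounds with values here, no step probes the position now changed, so in this assay no shift beyond the scatter is firmly expected; a small lower number is the working estimate, a 1.2-fold lower number from compound 1 to compound 4 (0.09 log units; within the scatter). Compound 4 is expected to give about 3500 nM, within 1500 nM to 8000 nM.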

Compound 4, half-maximal effective concentration: 9600 nM
Beside the measured number, compound 4's estimate is 2.7-fold (0.44 log units) below it; the measured number lies above the stated range.
By their numbers in this assay, from the lowest: compound 3; then compounds 1, 2 and 4 (each within the scatter of the next, the first and the last beyond it).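

In this assay, fluoro in place of hydrogen meta to a fluoro group and para to a group of 9 heavy atoms raises the number, with a 2.2-fold higher number from compound 1 to compound 4 (0.35 log units; beyond the scatter). The same change placed elsewhere on that ring went the other way, with a 3.1-fold lower number from compound 1 to compound 3 (0.49 log units; beyond the scatter), so among these compounds its direction depends on where it sits. Nothing available explains this reversal.

Still open, from the compounds shown here alone, is whether a chloro or methoxy group at this place would also raise the number. Whether an amine there would do the same is equally unsettled.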